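A few compounds are considered here, and "the series" means these few. Any claim that something is new, unique, unknown or untested is made for them only; others in the source may bear on it.

In a functional assay on PC-3 cells (Homo sapiens) for antiproliferative activity, read by MTT assay, with a stated time of 72 h (on this read-out lower numbers stand for stronger inhibition and higher numbers for weaker inhibition), compound 3 `CCC/C=C/C(=O)Nc1cc2c(N3CCCc4ccccc43)ncnc2cc1O[C@@H]1CCOC1` gives 11800 nM, the highest of the three numbers, although compound 1 lies within the scatter of it. Compound 1 `CCC/C=C/C(=O)Nc1cc2c(N3CCc4ccccc43)ncnc2cc1O[C@@H]1CCOC1` gives 9230 nM, and a 1.3-fold higher number from compound 1 to compound 3 (0.11 log units; within the scatter). Compound 2 `CCC/C=C/C(=O)Nc1cc2c(N3CCCc4ccccc43)ncnc2cc1OC` gives 2240 nM, and a 5.3-fold higher number from compound 2 to compound 3 (0.72 log units; beyond the scatter). Compound 4 `O=C(/C=C/CN1CCCCC1)Nc1cc2c(N3CCCc4ccccc43)ncnc2cc1O[C@@H]1CCOC1` differs from compound 3 in one place: piperidin-1-yl in place of ethyl on a saturated chain carbon bound to a double-bonded chain carbon. Neither measured step touches this part of the molecule; one swaps the ring attached to the core, the other the group on an oxygen on an aromatic ring, so nothing measured tells how this assay responds to this change. For compound 4 the estimated step is a 2.4-fold lower number from compound 3 to compound 4 (0.37 log units; beyond the scatter), an expectation with a wide range rather than a trend. Compound 4 is expected to give 5000 nM, between 1200 nM and 20000 nM.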

Compound 4, half-maximal inhibitory concentration: 3630 nM
The estimate for compound 4 lay 1.4-fold (0.14 log units) above the measured number; the range from low to high includes it.
By their numbers in this assay, from the lowest: compounds 2 and 4 (each within the scatter of the next); then compounds 1 and 3 (each within the scatter of the next).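

Among these compounds, this is the first measured change on a saturated chain carbon bound to a double-bonded chain carbon, and it registers: in this assay, piperidin-1-yl in place of ethyl gives a 3.3-fold lower number from compound 3 to compound 4 (0.51 log units; beyond the scatter). The larger group, with its six-membered ring and nitrogen, is therefore accepted here without a weaker number. Nothing available explains this step.

Still open, from the compounds shown here alone, is whether the ring or the nitrogen matters, which cyclohexyl or dimethylamino at this place could help separate. Also open, going by these compounds, is whether the step recurs with the methyl on oxygen of compound 2.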